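Notes on the step from compound 3 to compound 4

The compounds below may be only part of what the source reports. "The series", "measured", "known", "first", "only" and "open" are said of these compounds alone.

Compound 1 `COc1ccc(/C=C(\C(=O)c2ccc(Br)cc2)S(=O)(=O)c2ccc(Br)cc2)cc1` gives 25000 nM
Compound 2 `O=C(/C(=C\c1ccc(Cl)c([N+](=O)[O-])c1)S(=O)(=O)c1ccc(Br)cc1)c1ccc(Br)cc1` gives 10000 nM
Compound 3 `O=C(/C(=C\c1ccc(I)cc1)S(=O)(=O)c1ccc(Br)cc1)c1ccc(Br)cc1` gives 1000 nM

In a functional assay on DU-145 cells (Homo sapiens) for inhibition, read by trypan blue exclusion, with a stated time of 96 h (a lower number here means a stronger inhibitor of growth, a higher number a weaker inhibitor of growth), compound 3 has the lowest of the three numbers, and both gaps to it lie beyond the scatter. Compound 4 `COc1ccc(/C=C(\C(=O)c2ccc(Br)cc2)S(=O)(=O)c2ccc(Br)cc2)c(OC)c1` differs from it by 2,4-dimethoxyphenyl in place of 4-iodophenyl on a double-bonded chain carbon bound to a double-bonded chain carbon with 2,4-dimethoxyphenyl in place of 4-iodophenyl on a double-bonded chain carbon. The nearest evidence is a 25-fold lower number from compound 1 to compound 3 (1.40 log units; beyond the scatter) with iodo in place of methoxy on an aromatic carbon, a large step that compound 4 partly walks back. The other replacement of 4-iodophenyl, seen in a 10-fold lower number from compound 2 to compound 3 (1.00 log units; beyond the scatter), is modest and points the same way. For the measured compounds named here, no measured compound carries 2,4-dimethoxyphenyl, so the contribution of the second methoxy remains unknown. A rise in this assay beyond the scatter is therefore expected, of modest to large size, and the expected move is a 12-fold higher number from compound 3 to compound 4 (1.08 log units; beyond the scatter) in estimate. The estimate for compound 4 is 12000 nM with an expected range from 3000 nM to 40000 nM in this assay.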

Compound 4, concentration for 50% growth inhibition: 8000 nM
Beside the measured number, compound 4's estimate is 1.5-fold (0.18 log units) above it; low and high end bracket the measured number.
By their numbers in this assay, from the lowest: compound 3; then compounds 4 and 2 (each within the scatter of the next); then compound 1.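

In this assay, the step to 2,4-dimethoxyphenyl on this double-bonded chain carbon gives an 8.0-fold higher number from compound 3 to compound 4 (0.90 log units; beyond the scatter), so 4-iodophenyl keeps a lead over a second kind of ring that carries methoxy groups. For the compounds shown here, the added methoxy is a change the earlier compounds did not show, and it gives a 3.1-fold lower number from compound 1 to compound 4 (0.49 log units; beyond the scatter), so methoxy substitution at this position does not fix the number at the level of compound 1, while a 1.3-fold lower number from compound 2 to compound 4 (0.10 log units; within the scatter) leaves 2,4-dimethoxyphenyl and 4-chloro-3-nitrophenyl with no separation. No data on hand bear on the reason for these differences.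

Open, on these data alone, is how an amine, a carboxylic acid or a bromo group in place of the iodo would compare with compound 3 in this assay. As far as these compounds go, the bromo-bearing rings stay the same throughout, so whether these steps hold on a changed core also remains open.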